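The compounds below may be only part of what the source reports. "The series", "measured", "known", "first", "only" and "open" are said of these compounds alone.

The shared core carries a substituent on an aromatic carbon of a six-membered aromatic ring of carbon only, ortho to a large group. Compound 1 `Cc1ccccc1C(=O)/C=C/CCc1ccccc1` gives 2630 nM in a functional assay on HEK293 cells for antagonist activity at G-protein coupled receptor 52 (Homo sapiens), read by cAMP accumulation, with stated times of 15 min and 30 min; on this read-out lower numbers stand for stronger inhibition and higher numbers for weaker inhibition. Compound 2 `Cc1cccc(C)c1C(=O)/C=C/CCc1ccccc1` gives 2820 nM in this assay, and compound 3 `COc1ccccc1C(=O)/C=C/CCc1ccccc1` gives 1720 nM in this assay. Compound 3 shows the lowest of the three numbers, though its gaps to compound 1 and to compound 2 are both within the scatter, so the three cannot be ordered. Compound 4 `O=C(/C=C/CCc1ccccc1)c1ccccc1F` differs from compound 3 by fluoro in place of methoxy on an aromatic carbon. The measured step that bears on this is the one at the same place, a 1.5-fold lower number from compound 1 to compound 3 (0.18 log units; within the scatter). The other measured step, a 1.1-fold higher number from compound 1 to compound 2 (0.03 log units; within the scatter), likewise stays within the scatter. Since both measured changes at this position lie within the scatter, the change to compound 4 is expected to give no step beyond the scatter in this assay, which would mean a 1.3-fold higher number from compound 3 to compound 4 (0.11 log units; within the scatter). Compound 4 is therefore estimated at 2200 nM, with a range from 900 nM to 5500 nM.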

Compound 4, half-maximal inhibitory concentration: 1760 nM
Compound 4: the middle estimate sits 1.3-fold (0.10 log units) above what was measured; low and high end bracket the measured number.
By their numbers in this assay, from the lowest: compounds 3, 4, 1 and 2 (each within the scatter of the next).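

In this assay, fluoro in place of methoxy gives a 1.0-fold higher number from compound 3 to compound 4 (0.01 log units; within the scatter) and fluoro in place of methyl gives a 1.5-fold lower number from compound 1 to compound 4 (0.17 log units; within the scatter) at the same place on the aromatic ring. This place, ortho to a large group, has now taken a halogen as well as methyl and methoxy, with no listed step between these compounds lying beyond the scatter. Going from methoxy to fluoro removes one heavy atom and the one hydrogen-bond acceptor counted for that group, yet the number stays within the scatter, and no measurement on hand offers a cause for this flat response.

As far as these compounds go, it remains open whether any group at this place, such as an amine, a carboxylic acid or a longer chain, would give a step beyond the scatter. From the compounds shown here alone, it also remains open whether changes to the carbonyl or the chain of the shared core would do so.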